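A few compounds are considered here, and "the series" means these few. Any claim that something is new, unique, unknown or untested is made for them only; others in the source may bear on it.

Compound 1 `N#Cc1ccc(NC(=O)c2ccc3cccnc3c2O)c(F)c1`: 730 nM
Compound 2 `N#Cc1ccc(NC(=O)c2cc(Br)c3cccnc3c2O)cc1`: 330 nM

Both compounds were tested in a functional assay on HL-60 cells (Homo sapiens) for cytotoxicity, read by luminescence and CellTiter-Glo, with a stated time of 3 days; on this read-out higher numbers stand for weaker inhibition and lower numbers for stronger inhibition. Of the two numbers available, compound 1 has the higher at 730 nM, which places it on the weaker side of this small set. Compound 2 gives 330 nM, and the gap between the two lies beyond the usual scatter. However, the two compounds differ in more than one place, so their values do not isolate the effect of any single change.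

The next compound is compound 3 `Cc1cc(C#N)ccc1NC(=O)c1ccc2cccnc2c1O`, which keeps the core of compound 1 and its cyano group. The structural change is methyl in place of fluoro on an aromatic carbon, ortho to a large group and meta to a cyano group. For the measured compounds named here, no measured pair shows this exchange, so the data offer no direct precedent, and the expectation in this assay is for no step beyond the scatter. The estimated change is a 1.1-fold higher number from compound 1 to compound 3 (0.04 log units; within the scatter). For compound 3 the expected value is 800 nM, with an estimated range from 250 nM to 2500 nM.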

Compound 3, half-maximal inhibitory concentration: 710 nM
Beside the measured number, compound 3's estimate is 1.1-fold (0.05 log units) above it; measured number inside the range.
By their numbers in this assay, from the lowest: compound 2; then compounds 3 and 1 (each within the scatter of the next).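

In this assay, for the compounds shown here, methyl in place of fluoro on an aromatic carbon, ortho to a large group and meta to a cyano group, gives a 1.0-fold lower number from compound 1 to compound 3 (0.01 log units; within the scatter) and is the only step here that changes one place alone. The earlier two compounds differed in more than one place and isolated no single change, whereas this pair shows that the read-out does not separate fluoro from methyl at this position, with the rest of compound 1 held constant. No measured finding is available to explain this result.

The compounds shown leave open whether any other group at this position, such as a methoxy, an amine or a longer chain such as propyl, or plain hydrogen, would move the number beyond the scatter, so the result describes only this one exchange and not the position as a whole. Also open, as far as these compounds go, is what the bromo group of compound 2 contributes on its own, and whether it would act in the same way with the methyl group of compound 3 in place.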